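From propyl to butyl on the shared core

The source may report more compounds than this note shows. Statements on the series, on what has been measured and on what is new or still open speak of the compounds shown alone.

Compound 1 `N=C(NCCCCCCNC(=N)NC(=N)Nc1cccc(C(F)(F)F)c1)NC(=N)Nc1cccc(C(F)(F)F)c1` gives 5.12
Compound 2 `CCCCCCCCCCCCNC(=N)NC(=N)Nc1ccc(Cl)cc1` gives 7.13
Compound 3 `CCCNC(=N)NC(=N)Nc1ccc(Cl)cc1` gives 2.63

In a physicochemical assay for lipophilicity, in phosphate buffer, measured as octanol-water partition, at pH 11.5 (a lower number here means a more polar compound, a higher number a more lipophilic compound), compound 3 stands lowest of the three at 2.63 while compound 1 is its nearest neighbour and compound 2 its furthest, both gaps beyond the usual scatter. Compound 4 `CCCCNC(=N)NC(=N)Nc1ccc(Cl)cc1` is still unmeasured. It differs from compound 3 by one change methyl in place of hydrogen on a saturated chain carbon, three bonds along the chain from an amine nitrogen in which methyl takes the place of hydrogen on a saturated chain carbon, three bonds along the chain from an amine nitrogen, turning propyl to butyl. Compound 2 has the same core with a far longer chain and reaches 7.13 in this assay on that comparison alone. An upward step a number 0.50 log units higher from compound 3 to compound 4 (beyond the scatter) is expected, small but probably just beyond the scatter. Compound 4 is expected at 3.13 with a range from 2.8 to 3.5 in this estimate.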

Compound 4, partition coefficient: 3.13
The estimate for compound 4 equals the measured number at the digits printed; low and high end bracket the measured number.
By their numbers in this assay, from the lowest: compound 3; then compound 4; then compound 1; then compound 2.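

In this assay, methyl in place of hydrogen on a saturated chain carbon, three bonds along the chain from an amine nitrogen, turns propyl to butyl and gives a number 0.50 log units higher from compound 3 to compound 4 (beyond the scatter). Among the compounds shown here, this is the first single-place reading at this position. Hydrogen in place of octyl gives a number 4.00 log units lower from compound 2 to compound 4 (beyond the scatter), so among compound 2, compound 3 and compound 4 the number rises with chain length.

As far as these compounds go, whether an amine or a carboxylic acid at the chain end would shift the number remains open. Nothing available explains the size of either step.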